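Benzamide trifluoromethyl removal in a weakly active pyrazole series

The source may hold more compounds than are shown below. What is called first, only, known or untested is meant among the compounds shown, and "the series" means these compounds.

Compound 1 `COc1cc(-c2nn(-c3cccc(NC(=O)c4cccc(C(F)(F)F)c4)c3)cc2-c2ccncc2)ccc1Cl` in a functional assay on T47D cells (Homo sapiens) for inhibition, read by sulforhodamine B assay, with a stated time of 48 h; on this read-out lower numbers stand for stronger inhibition of growth and higher numbers for weaker inhibition of growth: > 50000 nM, a limit of this assay.
Compound 2 `O=C(Nc1cccc(-n2cc(-c3ccncc3)c(-c3ccc(Cl)c(O)c3)n2)c1)Nc1cc(C(F)(F)F)cc(C(F)(F)F)c1` in this assay: 14000 nM.

Compound 1 stands only at a limit of this assay, where (the limit of > 50000 nM in this assay, at which 1 of the 2 values shown sits); no number is known for it. Compound 3 `COc1cc(-c2nn(-c3cccc(NC(=O)c4ccccc4)c3)cc2-c2ccncc2)ccc1Cl` differs from compound 1 by hydrogen in place of trifluoromethyl on an aromatic carbon. Going by the values given here, no step between measured compounds is available, so the size of this change is unknown. The step is expected to be small, a number no higher from compound 1 to compound 3 (the limit leaves the size open), within the scatter. Compound 3 is expected to give 50000 nM, between 15000 nM and 150000 nM, and may again register only as a limit.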

Compound 3, concentration for total growth inhibition: > 100000 nM
Compound 3: only a limit was reported; the forecaster's own chance of this, stated with the estimate: 60%; at least 2.0-fold (0.30 log units) between middle value and limit.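

No step can be read between compound 1 and compound 3, as both values are only limits. The compounds shown leave open whether hydrogen in place of trifluoromethyl changes growth inhibition at all.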